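Ester on the tetrazole-side phenyl of compound 3

The compounds below may be only part of what the source reports. "The series", "measured", "known", "first", "only" and "open" are said of these compounds alone.

Compound 3 `CC(Oc1ccc(-c2ccccc2)cc1)C(=O)Cn1nnc(-c2ccccc2)n1` carries a phenyl on the phenoxy side of the shared core. In an ADME assay on S9 fraction from liver (Rattus norvegicus) for metabolic stability, read by LC-MS, using NADPH, with a stated time of 30 min (a lower number here means that less of the compound is left, a higher number that more of the compound is left), compound 3 returns only a limit of the assay, < 5%, and stands at the limit of < 5% in this assay, at which 1 of the 3 values shown sits. The measured compounds around it are compound 1 `CCCCCCCCc1ccc(OC(C)C(=O)Cn2nnc(-c3ccccc3)n2)cc1`, which gives 40% in this assay, and compound 2 `CC(Oc1ccc(Oc2ccc(C(F)(F)F)cc2)cc1)C(=O)Cn1nnc(-c2ccccc2)n1`, which gives 6%. The two steps away from compound 1 are large: a number 34 percentage points lower from compound 1 to compound 2 (beyond the scatter) and a number at least 35 percentage points lower from compound 1 to compound 3 (beyond the scatter). Between compound 2 and compound 3 the step is a number at least 1 percentage points lower from compound 2 to compound 3 (that floor lies within the scatter).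

Compound 4 `COC(=O)c1ccc(-c2nnn(CC(=O)C(C)Oc3ccc(-c4ccccc4)cc3)n2)cc1` differs from compound 3 in one place: methoxycarbonyl in place of hydrogen on an aromatic carbon. Going by the values given here, none of the measured steps touches the phenyl on the tetrazole side, so no measured step bears directly on this change; the three measured steps all concern the other end of the core. Compound 3 stands at the limit, and the measured steps give no support for a rise beyond the scatter. Compound 4 is therefore expected to sit near the limit, and the estimated step of a number no lower from compound 3 to compound 4 (the limit leaves the size open) is none beyond the scatter. The estimate for compound 4 in this assay is 5%, between 0% and 15%, with a fair chance that only a limit is reported again.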

Compound 4, percent of the compound remaining: 21%
Compound 4: the middle estimate sits 16 percentage points below what was measured; the measured number lies above the stated range.
By their numbers in this assay, from the lowest: compound 2; then compound 4; then compound 1. At a limit, below all of these: compound 3.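

In this assay, adding methoxycarbonyl to the phenyl on the tetrazole side, para to a large group, gives a number at least 16 percentage points higher from compound 3 to compound 4 (beyond the scatter). Going by these compounds alone, the earlier steps all changed the other end of the shared core, so this is the first sign that the tetrazole-side phenyl can also shift the percent remaining, and that a compound at the floor of this assay can be lifted off it without touching the phenoxy side. The printed step is only a lower bound on the true change, because compound 3 returns a limit of the assay and not a number: the limit of < 5% in this assay, at which 1 of the 4 values shown sits.

The compounds shown do not tell whether the rise belongs to the methoxycarbonyl itself or would also come with a carboxylic acid, an amide or a nitrile at the same place, and nothing here explains why the percent remaining rises. Going by these compounds, it also remains open whether methoxycarbonyl at this place would do the same with octyl or 4-(trifluoromethyl)phenoxy on the phenoxy side, as in compound 1 and compound 2.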